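Chain extension on the shared core: toward compound 3

The compounds below may be only part of what the source reports. "The series", "measured", "known", "first", "only" and "open" are said of these compounds alone.

Compound 1 `CC(C)(C)c1ncc2c(N)c(C#N)c(N)nc2n1` and compound 2 `CCCCc1nc(C(C)(C)C)nc2nc(N)c(C#N)c(N)c12` share one core; in a physicochemical assay for solubility, in phosphate buffer, with a stated time of 18 h (a higher number here means a more soluble compound, a lower number a less soluble compound), compound 1 gives 37200 nM, and in this assay compound 2 gives 6000 nM. Among the compounds with values here, the single measured step is a 6.2-fold lower number from compound 1 to compound 2 (0.79 log units; beyond the scatter), so compound 2 holds the lower of the two numbers known so far, with compound 1 as its only neighbour.

Compound 3 `CC(C)(C)c1nc(CCCCCC#N)c2c(N)c(C#N)c(N)nc2n1` carries the change (cyanomethyl in place of hydrogen on a saturated chain carbon, four bonds along the chain from an aromatic carbon). The butyl of compound 2 is thereby lengthened, and a nitrile is added at the end of the chain. Within the data shown here, the step that bears on this is the one from compound 1 to compound 2, in which a chain grew on the core and the number fell by a modest but real amount; no measured step shows a nitrile added at the end of a saturated chain, so its contribution is unknown here. The chain growth alone points toward a further small loss of solubility, or nothing beyond the scatter.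

For compound 3 the step is estimated as a 1.5-fold lower number from compound 2 to compound 3 (0.18 log units; within the scatter). Compound 3 is thus expected to give about 4000 nM in this assay, in the range 1500 nM to 12000 nM.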

Compound 3, solubility: 6000 nM
Beside the measured number, compound 3's estimate is 1.5-fold (0.18 log units) below it; measured number inside the range.
By their numbers in this assay, from the lowest: compounds 2 and 3 (each within the scatter of the next); then compound 1.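

In this assay, the longer nitrile-tipped chain gives no change at the digits printed from compound 2 to compound 3 (within the scatter), so at this saturated chain carbon, four bonds along the chain from an aromatic carbon, cyanomethyl in place of hydrogen leaves the number within the scatter of the butyl compound. Read from the unsubstituted aromatic carbon, 5-cyanopentyl gives a 6.2-fold lower number from compound 1 to compound 3 (0.79 log units; beyond the scatter), the same printed size as a 6.2-fold lower number from compound 1 to compound 2 (0.79 log units; beyond the scatter), so among these three compounds the drop seen with butyl also appears with the longer, nitrile-ended chain, and the change further out on the chain adds no further step beyond the scatter. No supporting measurement is available to explain this flat step, and the result stands here as an observation only.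

The added chain carbons and the nitrile enter together in this step, so the compounds shown do not separate their contributions; a plain hexyl or a longer unbranched alkyl chain at this position would bear on that. Going by these compounds, how a primary amine or a carboxylic acid at the chain end would compare with the nitrile also remains open.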